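A Side-Chain Change Carried Over to a Second Core

This account rests on a few compounds, and the source may have more. Where it says the series, first, only, none or still open, it means among the compounds named here.

Compound 1 `Cc1cc(/C=C/C#N)cc(C)c1Oc1nc(Nc2ccc(N3CCCC(NS(C)(=O)=O)C3)cc2)nc2sccc12` gives 112000 nM in an ADME assay on MT4 cells (Homo sapiens) for cytotoxicity, read by MTT assay, with a stated time of 5 days; on this read-out lower numbers stand for higher toxicity in this test and higher numbers for lower toxicity in this test.
Compound 2 `Cc1cc(/C=C/C#N)cc(C)c1Oc1nc(Nc2ccc(CN3CCN(S(N)(=O)=O)CC3)cc2)nc2ccsc12` gives 145000 nM in this assay.
Compound 3 `Cc1cc(/C=C/C#N)cc(C)c1Oc1nc(Nc2ccc(CN3CCN(S(N)(=O)=O)CC3)cc2)nc2sccc12` reaches only a limit of the method, > 217000 nM, in this assay.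

Compounds 1 and 3 share one core, and compound 3 stands at the limit of > 217000 nM in this assay, at which 1 of the 3 values shown sits. The change between them, (3-(methanesulfonamido)piperidin-1-yl in place of (4-sulfamoylpiperazin-1-yl)methyl on an aromatic carbon), gives an at least 1.9-fold lower number from compound 3 to compound 1 (0.28 log units; that floor lies within the scatter). Compound 2 carries the other core; how the two cores differ is not broken down here. Compound 2 and compound 1 are within the usual scatter of each other in this assay.

Compound 4 `Cc1cc(/C=C/C#N)cc(C)c1Oc1nc(Nc2ccc(N3CCCC(NS(C)(=O)=O)C3)cc2)nc2ccsc12` has not been measured. It relates to compound 2 as compound 1 relates to compound 3: 3-(methanesulfonamido)piperidin-1-yl in place of (4-sulfamoylpiperazin-1-yl)methyl on an aromatic carbon, the same change at the same place. The step from compound 3 to compound 1 sits at a floor that lies inside the scatter, so only a modest move is expected. From compound 2, which gives 145000 nM, the expected step is a 1.5-fold lower number from compound 2 to compound 4 (0.18 log units; within the scatter). Compound 4 is therefore estimated at 95000 nM in this assay, with a likely range from 40000 nM to 220000 nM.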

Compound 4, half-maximal cytotoxic concentration: > 217000 nM
Compound 4 was reported as a limit; the forecaster's own chance of this, stated with the estimate: 10%; at least 2.2-fold (0.35 log units) between middle value and limit.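

In this assay compound 4 reaches > 217000 nM, which is a limit of the method and not a number. On the core of compound 2 the change gives an at least 1.4-fold higher number from compound 2 to compound 4 (0.17 log units; that floor lies within the scatter), and it does not run the same way as on the core of compound 1: the same change on two cores in this assay, an at least 1.9-fold lower number (0.28 log units; that floor lies within the scatter) from compound 3 to compound 1 and an at least 1.4-fold higher number (0.17 log units; that floor lies within the scatter) from compound 2 to compound 4, at least 2.8-fold (0.46 log units) apart, beyond the scatter of two such steps This shows that, within these two pairs, the outcome of the change in this assay depends on the core it sits on, although neither step alone leaves the scatter; it does not show the true size of either step, or why the cores differ, and two of the values are limits: the limit of > 217000 nM in this assay, at which 2 of the 4 values shown sit.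

The compounds shown leave open whether the same change would follow either pattern on a third core. They also leave open how a different group on the same aromatic carbon, such as a carboxylic acid or a simple amine, would fare on these two cores.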